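The source may hold more compounds than are shown below. What is called first, only, known or untested is meant among the compounds shown, and "the series" means these compounds.

Measured in a functional assay, read by spectrophotometry, with a stated time of 30 min; a higher number here means a weaker inhibitor, a lower number a stronger inhibitor:
Compound 1 `O=C(/C=C/c1ccccc1)NCCC1CCN(Cc2ccccc2)CC1`: > 200000 nM, a limit of the assay and not a number
Compound 2 `CC(C)(C)c1cc(CCC(=O)NCCC2CCN(Cc3ccccc3)CC2)cc(C(C)(C)C)c1O`: 54500 nM
Compound 3 `Cc1ccc(CN2CCC(CCNC(=O)/C=C/c3cc(C(C)(C)C)c(O)c(C(C)(C)C)c3)CC2)cc1`: 60400 nM

Compound 3 has a numerical value in this assay, and its nearest neighbour is compound 2. The two values lie within the usual scatter of each other, so they cannot be separated. Compound 1 gives no number to compare with, only a limit.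

The next compound to be tested is compound 4 `CC(C)(C)c1cc(/C=C/C(=O)NCCC2CCN(Cc3ccccc3Cl)CC2)cc(C(C)(C)C)c1O`. It has 2-chlorophenyl in place of 4-methylphenyl on a saturated chain carbon bound to an amine nitrogen in a ring, which is the same as 4-methylbenzyl to 2-chlorobenzyl: 2-chlorophenyl in place of 4-methylphenyl on a saturated chain carbon bound to an amine nitrogen in a ring. Among the compounds with values here, no measured pair in this small set shows what such an exchange does, so the expectation rests on compound 3 at 60400 nM and on the fact that the change is confined to this one group. A small step in this assay is expected, leaning towards a stronger inhibitor but probably not clearly beyond the scatter. The estimated change is a 1.5-fold lower number from compound 3 to compound 4 (0.18 log units; within the scatter). For compound 4 the estimated value is 40000 nM, with an expected range of 12000 nM to 130000 nM.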

Compound 4, half-maximal inhibitory concentration: 80200 nM
The estimate for compound 4 lay 2.0-fold (0.30 log units) below the measured number, and the stated range covers the measured number.
By their numbers in this assay, from the lowest: compounds 2, 3 and 4 (each within the scatter of the next). At a limit, above all of these: compound 1.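

In this assay, the exchange of 4-methylphenyl for 2-chlorophenyl, on a saturated chain carbon bound to an amine nitrogen in a ring, gives a 1.3-fold higher number from compound 3 to compound 4 (0.12 log units; within the scatter). Within the data shown here, this is the first step in the set that can be read at this position, and it shows that replacing one group with another of the same heavy-atom count leaves compound 3 and compound 4 inseparable in this assay. No measurement shown gives a reason for this result.

As far as these compounds go, a single step cannot show how each part of the exchange contributes, since the methyl group leaves and the chlorine enters at a different ring position in the same move, so the effect of either one alone remains unknown. It also remains open whether a larger departure at this position, such as a pyridine ring, a cyclohexyl group or a carboxylic acid in place of 2-chlorophenyl, would produce a step beyond the scatter, as the one exchange shown here cannot establish a pattern for the position as a whole.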